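The source may report more compounds than this note shows. Statements on the series, on what has been measured and on what is new or still open speak of the compounds shown alone.

Measured compounds:
Compound 1, `CCCC(C)n1c(=O)c(C)nc2c(-c3ccc(Cl)cc3Cl)ccnc21` — 62 nM
Compound 2, `CC[C@@H](C1CC1)n1c(=O)c(C)nc2c(-c3ccc(Cl)cc3Cl)nccc21` — 55 nM
Compound 3, `Cc1nc2c(-c3ccc(Cl)cc3Cl)ccnc2n(C(C)C(C)C)c1=O` — 380 nM

In a functional assay for antagonist activity at corticotropin-releasing factor receptor 1 (Rattus norvegicus) (on this read-out higher numbers stand for weaker inhibition and lower numbers for stronger inhibition), compound 2 gives the lowest of the three numbers, but its gap to compound 1 lies within the scatter, so the two cannot be separated; only compound 3 stands clearly apart, with a higher number than both. The unmeasured compound 4, `CC[C@H](COC)n1c(=O)c(C)nc2c(-c3ccc(Cl)cc3Cl)nccc21`, differs from compound 2 in one place: 1-(methoxymethyl)propyl in place of 1-cyclopropylpropyl on an aromatic nitrogen. Among the compounds with values here, the only measured step, a 6.1-fold higher number from compound 1 to compound 3 (0.79 log units; beyond the scatter), changes the group on the same aromatic nitrogen in a different core and bears on this step only loosely; it shows that altering the chain branching at that position can move this assay by a modest amount. Within the data shown here, the change from compound 2 to compound 4 keeps a branched chain of the same size but exchanges the three-membered ring for a chain carrying one hydrogen-bond acceptor, and no measured pair speaks directly to such an exchange. Compound 4 is therefore expected to remain close to compound 2, with a step of a 1.5-fold higher number from compound 2 to compound 4 (0.19 log units; within the scatter) that may or may not exceed the scatter. The estimate for compound 4 is 85 nM, expected to fall between 30 nM and 250 nM.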

Compound 4, half-maximal inhibitory concentration: 150 nM
Estimate against measurement, compound 4: 1.8-fold (0.25 log units) below; the range from low to high includes it.
By their numbers in this assay, from the lowest: compounds 2 and 1 (each within the scatter of the next); then compound 4; then compound 3.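

In this assay, within the data shown here, replacing 1-cyclopropylpropyl with 1-(methoxymethyl)propyl on the aromatic nitrogen gives a 2.7-fold higher number from compound 2 to compound 4 (0.44 log units; beyond the scatter), the first measured step at this position on the core of compound 2. Both groups count 6 heavy atoms and carry 1 defined stereocentre, so the step shows that this position does not respond to the number of heavy atoms alone: two groups of equal count, one with a three-membered ring and the other with an oxygen and no ring, lie beyond the scatter of each other. The change removes the ring and adds a hydrogen-bond acceptor in one move, so the step cannot be assigned to either part, and nothing available here offers an explanation for it.

From the compounds shown here alone, it remains open whether a 1-ethylpropyl group, which has neither the ring nor the oxygen, would give a number nearer that of compound 2 or that of compound 4. Going by these compounds, it is equally open how a hydroxymethyl group or a longer ether chain in place of the methoxymethyl part would read in this assay.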